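Piperidin-1-yl for isopropyl(methyl)amino on compound 3

The compounds below may be only part of what the source reports. "The series", "measured", "known", "first", "only" and "open" are said of these compounds alone.

Values in an ADME assay on MT4 cells (Homo sapiens) for cytotoxicity, read by MTT assay, with a stated time of 4 days; on this read-out lower numbers stand for higher toxicity in this test and higher numbers for lower toxicity in this test:
Compound 1 `Cc1c(Cc2c(F)cccc2F)nc(N(C)C(C)C)[nH]c1=O`: 79000 nM
Compound 2 `Cc1c(Cc2c(F)cccc2F)nc(N2CCCCC2)[nH]c1=O`: > 78000 nM (a limit)
Compound 3 `Cc1c(C(C)c2c(F)cccc2F)nc(N(C)C(C)C)[nH]c1=O`: > 81000 nM (a limit)

Compound 3 has no exact number: its > 81000 nM is a limit of the assay. Compound 4 `Cc1c(C(C)c2c(F)cccc2F)nc(N2CCCCC2)[nH]c1=O` carries piperidin-1-yl in place of isopropyl(methyl)amino on an aromatic carbon.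

The same exchange has been measured once, as a step that the limit leaves unreadable from compound 1 to compound 2. That step sets no size for the exchange, yet it gives no sign of a fall. The other measured change, methyl in place of hydrogen on a saturated chain carbon bound to two aromatic carbons, appears as an at least 1.0-fold higher number from compound 1 to compound 3 (0.01 log units; that floor lies within the scatter). Neither step points to a real shift, so in this assay no step beyond the scatter is expected. The expected change is an at least 1.0-fold lower number from compound 3 to compound 4 (0.01 log units; that floor lies within the scatter). A report of only a limit is the likeliest result. For compound 4 the estimate is 78000 nM, with an expected range from 40000 nM to 120000 nM.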

Compound 4, half-maximal cytotoxic concentration: > 75000 nM
Compound 4 gave a limit, no number; the forecaster's own chance of this, stated with the estimate: 75%; the middle value is on the limit's open side.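

In this assay compound 4 gives > 75000 nM, which is a limit. Compound 2 and compound 3 also gave limits, and neither step to compound 4, from compound 3 or from compound 2, can be read. The compounds shown leave open how the values of compound 2, compound 3 and compound 4 stand relative to one another.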